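The source may hold more compounds than are shown below. What is called first, only, known or untested is meant among the compounds shown, and "the series" means these compounds.

Measured compounds:
compound 1 `CC#C[C@H]1CN(S(=O)(=O)c2ccc(N)nc2)CCN1c1ccc(S(=O)(=O)NCC2CC2)cc1` gives 213 mL.min-1.g-1 in an ADME assay (liver) for metabolic stability, with Liver microsome (Rattus norvegicus) as the target, using microsomes and NADPH, with a stated time of 30 min; on this read-out lower numbers stand for slow clearance and higher numbers for fast clearance;
compound 2 `CC#C[C@H]1CN(S(=O)(=O)c2ccc(N)nc2)CCN1c1ccc(S(N)(=O)=O)cc1` gives 30 mL.min-1.g-1 in this assay;
compound 3 `C#CCC(O)(c1ccc(N2CCN(S(=O)(=O)c3ccc(N)nc3)C[C@@H]2C#CC)cc1)C(F)(F)F` gives 59 mL.min-1.g-1 in this assay.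

Compound 3 stands second highest of the three numbers: compound 1 sits higher, as the step of a 3.6-fold lower number from compound 1 to compound 3 (0.56 log units; beyond the scatter) shows, while compound 2 lies within the scatter of it, as a 2.0-fold higher number from compound 2 to compound 3 (0.29 log units; within the scatter) shows. Compound 4 `CC#C[C@H]1CN(S(=O)(=O)c2ccc(N)nc2)CCN1c1ccc([C@](O)(CO)C(F)(F)F)cc1` differs from compound 3 by a group of 8 heavy atoms (3 carbon, 2 oxygen, 3 fluorine; no ring) in place of a group of 9 heavy atoms (5 carbon, 1 oxygen, 3 fluorine; no ring), on an aromatic carbon. Among the compounds with values here, the steps that bear on this change are a 7.1-fold lower number from compound 1 to compound 2 (0.85 log units; beyond the scatter) and a 3.6-fold lower number from compound 1 to compound 3 (0.56 log units; beyond the scatter), both trimming a group on the same aromatic carbon and both giving modestly lower numbers. A smaller group on that carbon is therefore expected to give a lower number in this assay, though the step may not clear the scatter. Compound 4 is expected to give 35 mL.min-1.g-1, within 15 mL.min-1.g-1 to 80 mL.min-1.g-1, an expected step of a 1.7-fold lower number from compound 3 to compound 4 (0.23 log units; within the scatter).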

Compound 4, intrinsic clearance in microsomes: < 14 mL.min-1.g-1
Compound 4: only a limit was reported; the forecaster's own chance of this, stated with the estimate: 5%; middle value at least 2.5-fold (0.39 log units) away from the limit.
By their numbers in this assay, from the lowest: compounds 2 and 3 (each within the scatter of the next); then compound 1. At a limit, below all of these: compound 4.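

Compound 4 is reported only as a limit of this assay: the limit of < 14 mL.min-1.g-1 in this assay, at which 1 of the 4 values shown sits. Compound 2 and compound 3 had stood within the scatter of each other, but 1,2-dihydroxy-1-(trifluoromethyl)ethyl on this aromatic carbon separates from all three earlier groups, with an at least 4.2-fold lower number from compound 3 to compound 4 (0.62 log units; beyond the scatter), an at least 2.1-fold lower number from compound 2 to compound 4 (0.33 log units; beyond the scatter) and an at least 15-fold lower number from compound 1 to compound 4 (1.18 log units; beyond the scatter). The number at this position can therefore go beyond the scatter of both lower earlier compounds.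

The compounds shown leave open whether the step follows the triple bond that leaves or the extra hydrogen-bond donor and acceptor that enter. They also leave open whether an amine or a longer chain on this carbon would give as low a number.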